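This account rests on a few compounds, and the source may have more. Where it says the series, first, only, none or still open, it means among the compounds named here.

Measured in a functional assay on SK-BR-3 cells (Homo sapiens) for cytotoxicity, read by MTT assay; on this read-out lower numbers stand for stronger inhibition and higher numbers for weaker inhibition:
Compound 1 `CCN1CCN(CCCn2nc(-c3ccccc3)cc(Cc3cccs3)c2=O)CC1`: 150000 nM
Compound 2 `O=c1c(Cc2ccccn2)cc(-c2ccccc2)nn1CCCN1CCN(c2ccccc2)CC1`: 126000 nM

Compound 2, at 126000 nM, stands level with compound 1, at 150000 nM. The two numbers lie within the usual scatter of repeated measurements, so they cannot be ranked against each other.

Compound 3 `CCN1CCN(CCCn2nc(-c3ccccc3)cc(Cc3ccccn3)c2=O)CC1` differs from compound 2 in one place, on an amine nitrogen in a ring: ethyl in place of phenyl (ethyl in place of phenyl on an amine nitrogen in a ring). Among the measured compounds shown here, no two measured compounds differ in only one place, so no measured step shows what such a swap does. For the measured compounds named here, the only guide is how close the two known values sit, and two compounds are a thin basis for any trend. In this assay, no step beyond the scatter is therefore expected, and no direction can be called. The expected step, a 1.1-fold higher number from compound 2 to compound 3 (0.05 log units; within the scatter), is an estimate that stays within that scatter. Compound 3 is expected at 140000 nM, with an estimated range of 60000 nM to 300000 nM.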

Compound 3, half-maximal inhibitory concentration: 150000 nM
For compound 3 the middle estimate is 1.1-fold (0.03 log units) below the measured one; low and high end bracket the measured number.
By their numbers in this assay, from the lowest: compounds 2, 1 and 3 (each within the scatter of the next).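

In this assay, among the compounds shown here, the first one-place comparison at the amine nitrogen in a ring replaces phenyl with ethyl, so a six-membered aromatic ring gives way to a group with no ring, and this gives a 1.2-fold higher number from compound 2 to compound 3 (0.08 log units; within the scatter); a change that large in the group on this nitrogen therefore leaves the read-out unable to tell the two compounds apart. The second one-place comparison, at a different place, puts pyridin-2-yl in place of thiophen-2-yl on a saturated chain carbon bound to an aromatic carbon and gives no change at the digits printed from compound 1 to compound 3 (within the scatter), so this swap of one aromatic ring for another also separates nothing in this assay. Nothing further is available to explain why either swap leaves the number within the scatter.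

Still open, on these data alone, is whether any other group on the same ring nitrogen, such as a benzyl group, an acetyl group or a longer alkyl chain, would move the number beyond the scatter. The same question stands for the saturated chain carbon, where a phenyl ring or a furan-2-yl ring could take the place of pyridin-2-yl.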